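Fluorophenyl to methyl on the ether chain

The source may hold more compounds than are shown below. What is called first, only, known or untested is meant among the compounds shown, and "the series" means these compounds.

Compound 3 `O=C1CC(c2ccccc2OCc2ccc(F)cc2)Oc2ccccc21` stands lowest of three compounds in a functional assay on RAW264.7 cells (Mus musculus) for inhibition, read by immunoassay, with a stated time of 12 h, tested at 30 uM (a higher number here means more inhibition at the concentration tested (going by the name of the read-out), a lower number less inhibition), where compound 3 gives 45.2%. Compound 1 `C=CCOc1ccccc1C1CC(=O)c2ccccc2O1` gives 49.3%, within the scatter of compound 3, whereas compound 2 `O=C1CC(c2ccccc2OCc2cccc(F)c2)Oc2ccccc21` gives 93.3%, and the step of a number 48.1 percentage points lower from compound 2 to compound 3 (beyond the scatter) lies beyond the scatter. Compound 4 `CCOc1ccccc1C1CC(=O)c2ccccc2O1` differs from compound 3 by methyl in place of 4-fluorophenyl on a saturated chain carbon bound to an oxygen on an aromatic ring. For the measured compounds named here, no measured step brings in a methyl, so the closest guide is a number 4.1 percentage points lower from compound 1 to compound 3 (within the scatter), a step within the scatter, while a number 44 percentage points higher from compound 1 to compound 2 (beyond the scatter) shows that 3-fluorophenyl in place of vinyl mattered greatly. Because a number 4.1 percentage points lower from compound 1 to compound 3 (within the scatter) stayed within the scatter, the expected step is a number 0.2 percentage points lower from compound 3 to compound 4 (within the scatter), none beyond the scatter. Compound 4 is therefore estimated at 45%, between 28% and 62%.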

Compound 4, a percentage reported as inhibition, at one concentration (the size of the read-out at that concentration, not a potency): 29.6%
Compound 4: the middle estimate sits 15.4 percentage points above what was measured, within the range that was stated.
By their numbers in this assay, from the lowest: compound 4; then compounds 3 and 1 (each within the scatter of the next); then compound 2.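

At this place, on a saturated chain carbon bound to an oxygen on an aromatic ring, vinyl and 4-fluorophenyl had read alike in this assay, yet methyl stands apart from both, with a number 15.6 percentage points lower from compound 3 to compound 4 (beyond the scatter) and a number 19.7 percentage points lower from compound 1 to compound 4 (beyond the scatter) as its steps. Changing the group here can thus lower the number as well as raise it, and a number 63.7 percentage points lower from compound 2 to compound 4 (beyond the scatter) is the widest step seen so far. No evidence on the cause of these steps is at hand. As far as these compounds go, whether a plain phenyl, an amine or a longer chain at this place would read nearer compound 2 or compound 4 stays open.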